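This account rests on a few compounds, and the source may have more. Where it says the series, first, only, none or still open, it means among the compounds named here.

Measured in a functional assay on SW480 cells (Homo sapiens) for antiproliferative activity, with a stated time of 72 h; a higher number here means a weaker inhibitor, a lower number a stronger inhibitor:
compound 1 `O=C(COc1ccc(CN2CC=C(c3c[nH]c4cccc(F)c34)CC2)c(F)c1)NO` gives 5560 nM
compound 2 `O=C(COc1ccc(CNC2CC=C(c3c[nH]c4cccc(F)c34)CC2)c(F)c1)NO` gives 189 nM
compound 3 `Cc1ccc2[nH]cc(C3=CCN(Cc4ccc(OCC(=O)NO)cc4F)CC3)c2c1` gives 1950 nM

Compound 1 has the highest number of the three and is thus the weakest inhibitor of this set in this assay. Compound 3 lies nearest to it, while compound 2 lies furthest away.

Compound 4 `O=C(COc1ccc(CN2CC=C(c3c[nH]c4cccc(F)c34)CC2)cc1)NO` has not yet been measured. It keeps the core of compound 1 and differs in one place. The change is hydrogen in place of fluoro on an aromatic carbon and amounts to hydrogen in place of fluoro on an aromatic carbon, ortho to a large group and meta to a (hydroxycarbamoyl)methoxy group.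

Among the measured compounds shown here, no measured step covers this change, since compounds 1, 2 and 3 all carry this fluoro group. For the measured compounds named here, the only measured step, a 2.9-fold lower number from compound 1 to compound 3 (0.46 log units; beyond the scatter), is modest but beyond the scatter. It concerns 5-methyl-1H-indol-3-yl in place of 4-fluoro-1H-indol-3-yl, so it serves only as a gauge of size for a small change. A step no larger than that one is therefore expected, with no firm direction. The estimated step is a 1.2-fold lower number from compound 1 to compound 4 (0.09 log units; within the scatter) and is expected to stay within the scatter. For compound 4 the estimate is 4500 nM with an expected range from 1800 nM to 11000 nM in this measurement.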

Compound 4, half-maximal inhibitory concentration: 2310 nM
Estimate against measurement, compound 4: 1.9-fold (0.29 log units) above, within the range that was stated.
By their numbers in this assay, from the lowest: compound 2; then compounds 3 and 4 (each within the scatter of the next); then compound 1.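

In this assay, among the compounds shown here, the fluoro group on the aromatic carbon ortho to a large group and meta to a (hydroxycarbamoyl)methoxy group can now be assessed for the first time, as compounds 1, 2 and 3 all carry it. Replacing it with hydrogen gives a 2.4-fold lower number from compound 1 to compound 4 (0.38 log units; beyond the scatter), so this carbon does influence the read-out, and the fluoro group is not required for antiproliferative activity in this series: the hydrogen compound is the stronger inhibitor of this pair, though the step is modest and rests on a single pair of compounds. The data shown offer no measured basis for explaining this step.

From the compounds shown here alone, how a chloro, methyl or methoxy group on the same carbon would compare with fluoro and hydrogen remains open, so it cannot be said whether the step follows from losing fluoro in particular or would be shared by other groups. Going by these compounds, it is also open whether hydrogen in place of fluoro would give a step of similar size and direction in the setting of compound 2 or of compound 3.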